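This account rests on a few compounds, and the source may have more. Where it says the series, first, only, none or still open, it means among the compounds named here.

Measured in a functional assay on RXF 393 cells (Homo sapiens) for cytotoxicity, read by sulforhodamine B assay, with a stated time of 48 h, tested at 100 nM; on this read-out higher numbers stand for a weaker effect at the one concentration tested and lower numbers for a stronger effect:
compound 1 `COc1cc(C)cc(-c2nn(CC#N)cc2-c2ccc(-c3cccc(C(C)=O)c3)nc2)c1` gives 73%
compound 2 `Cc1cc(O)cc(-c2nn(CC#N)cc2-c2ccnc(-c3ccc(Oc4ccccc4)cc3)c2)c1` gives 101%

Compound 2 stands at the highest of the two numbers in this assay; its nearest neighbour is compound 1, whose value lies lower by a gap beyond the scatter, so compound 2 shows the weaker effect of the two at the one concentration tested. Within the data shown here, no step between compounds differing in one place has been measured, so no calibrated step size exists in this set.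

The next compound, compound 3 `Cc1cc(O)cc(-c2nn(CC#N)cc2-c2ccnc(-c3ccc(N(C)C)cc3)c2)c1`, differs from compound 2 by dimethylamino in place of phenoxy on an aromatic carbon.

Among the measured compounds shown here, with no measured step of this kind to draw on, the change is treated as neutral: the step in this assay from compound 2 to compound 3 is expected to be small, within the scatter, with at most a slight lowering. Compound 3 is estimated to give 95% in this assay, in the range 75% to 110%, meaning an expected step of a number 6 percentage points lower from compound 2 to compound 3 (within the scatter).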

Compound 3, a percentage reported as activity, at one concentration (the size of the read-out at that concentration, not a potency): 120%
Estimate against measurement, compound 3: 25 percentage points below; measured number above the stated range.
By their numbers in this assay, from the lowest: compound 1; then compound 2; then compound 3.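

In this assay, among these compounds, the replacement of phenoxy by dimethylamino, on an aromatic carbon para to a large group, gives the first one-place comparison: a number 19 percentage points higher from compound 2 to compound 3 (beyond the scatter), which means a weaker effect at the one concentration tested. This position is therefore not indifferent to its substituent, and the smaller, ring-free dimethylamino does not bring a stronger effect than phenoxy here. The change swaps several features at once, since an aromatic ring leaves and the attached oxygen gives way to nitrogen, and nothing measured on these compounds accounts for the step or shows which feature matters.

Still open, going by these compounds, is how the read-out responds at this place to groups that separate those features, such as methoxy, which keeps the oxygen without the ring, or anilino, which keeps the ring with a nitrogen in place of the oxygen. Also open, on these data alone, is whether a step of this kind would hold on the core of compound 1, which differs from compound 2 in more than one place.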